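The source may report more compounds than this note shows. Statements on the series, on what has been measured and on what is new or still open speak of the compounds shown alone.

Three compounds have been tested in a functional assay on the whole organism (strain Wistar) for inhibition, with Rattus norvegicus as the target, read by paw edema, with stated times of 60 min and 6 h, at a dose of 100 mg/kg by the oral route; on this read-out higher numbers stand for more inhibition at the one dose given (going by the name of the read-out) and lower numbers for less inhibition:
compound 1 `COc1cc2c(cc1OC)C(CC(=O)N(C)C)CC2` gives 33.3%
compound 2 `CCNC(=O)CC1CCc2cc(OC)c(OC)cc21` gives 20.4%
compound 3 `COc1cc2c(cc1OC)C(CC(=O)NC(C)(C)C)CC2` gives 31.5%

Compound 3 stands second of the three: the step of a number 1.8 percentage points lower from compound 1 to compound 3 (within the scatter) lies within the scatter, while the step of a number 11.1 percentage points higher from compound 2 to compound 3 (beyond the scatter) lies beyond it. Compound 4 `COc1cc2c(cc1OC)C(CC(=O)NC1CCCC1)CC2` differs from compound 3 at one place only, on the amide-type nitrogen: cyclopentyl in place of tert-butyl on an amide-type nitrogen. The measured step at this same place is a number 11.1 percentage points higher from compound 2 to compound 3 (beyond the scatter), a modest rise when tert-butyl replaced ethyl; the step of a number 1.8 percentage points lower from compound 1 to compound 3 (within the scatter) shows that another exchange of the group on the amide nitrogen left the number within the scatter. With cyclopentyl and tert-butyl both unlike ethyl, the step of a number 0.5 percentage points higher from compound 3 to compound 4 (within the scatter) is expected to stay within the scatter. Compound 4 is therefore estimated at 32%, ranging from 20% to 44%.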

Compound 4, a percentage reported as inhibition, in the whole organism at one dose (the size of the read-out at that dose, not a potency): 40.7%
Beside the measured number, compound 4's estimate is 8.7 percentage points below it; the measured number falls inside the stated range.
By their numbers in this assay, from the lowest: compound 2; then compounds 3, 1 and 4 (each within the scatter of the next).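

In this assay, going by these compounds alone, a ring on the amide-type nitrogen now appears for the first time, and cyclopentyl gives a number 20.3 percentage points higher from compound 2 to compound 4 (beyond the scatter), the largest step seen at this place. The other two steps, a number 9.2 percentage points higher from compound 3 to compound 4 (within the scatter) and a number 7.4 percentage points higher from compound 1 to compound 4 (within the scatter), set no order among these compounds, so only the ethyl compound stands apart. Nothing available gives a reason for these steps. Open, from the compounds shown here alone, is whether a cyclohexyl ring, a piperidine ring or a longer chain such as n-butyl on this nitrogen would stay level with cyclopentyl or fall toward ethyl.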